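A few compounds are considered here, and "the series" means these few. Any claim that something is new, unique, unknown or untested is made for them only; others in the source may bear on it.

Compound 1 `Cc1ccc(-c2nn(-c3ccccc3)cc2-c2nc3ccccc3n2S(=O)(=O)c2ccc(C(F)(F)F)cc2)cc1`: 182000 nM
Compound 2 `O=S(=O)(c1ccc(F)cc1)n1c(-c2cn(-c3ccccc3)nc2-c2ccc(F)cc2)nc2ccccc21`: 218000 nM

In an ADME assay on HEK-293T cells (Homo sapiens) for cytotoxicity, read by MTT assay, with a stated time of 24 h (on this read-out higher numbers stand for lower toxicity in this test and lower numbers for higher toxicity in this test), compound 2 gives 218000 nM and compound 1 gives 182000 nM, two values within the usual scatter of each other. Compound 3 `O=S(=O)(c1ccc(C(F)(F)F)cc1)n1c(-c2cn(-c3ccccc3)nc2-c2ccc(F)cc2)nc2ccccc21` differs from compound 2 in one place: trifluoromethyl in place of fluoro on an aromatic carbon. In words, trifluoromethyl stands in place of fluoro on an aromatic carbon, para to a large group. For the measured compounds named here, no measured pair shows this change alone, so its effect cannot be read directly from the data. A step beyond the scatter is not expected. The estimated step of a 1.1-fold lower number from compound 2 to compound 3 (0.06 log units; within the scatter) is expected to stay within the scatter. The estimate for compound 3 is 190000 nM, with an expected range of 100000 nM to 350000 nM.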

Compound 3, half-maximal cytotoxic concentration: 241000 nM
Compound 3: the middle estimate sits 1.3-fold (0.10 log units) below what was measured; measured number inside the range.
By their numbers in this assay, from the lowest: compounds 1, 2 and 3 (each within the scatter of the next).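

In this assay, for the compounds shown here, 4-(trifluoromethyl)phenyl in place of 4-fluorophenyl gives a 1.1-fold higher number from compound 2 to compound 3 (0.04 log units; within the scatter) and so provides the first direct reading of this change at this position. At a second place on the shared core, fluoro in place of methyl on an aromatic carbon gives a 1.3-fold higher number from compound 1 to compound 3 (0.12 log units; within the scatter) as the other single-place comparison. Neither change moves the number beyond the scatter. On these data alone, whether an amine or a carboxylic acid at the first position would do the same remains open. Nothing here explains why these changes give such small steps.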